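A few compounds are considered here, and "the series" means these few. Any claim that something is new, unique, unknown or untested is made for them only; others in the source may bear on it.

Working notes on the series.

Three compounds have numbers in an assay on cell membranes for displacement of a labelled ligand from Sigma non-opioid intracellular receptor 1 (Cavia porcellus), read by scintillation counting; a higher number here means a weaker inhibitor, a lower number a stronger inhibitor. Compound 1 `CCN(CC)CCCC(C)NC(C)c1cc2c(cc1OC)OC(C)(C)C=C2` gives 192 nM. Compound 2 `COc1cc2c(cc1C(C)NCc1ccccc1)CCC(C)(C)O2` gives 119 nM. Compound 3 `COc1cc2c(cc1C(C)NCCCc1ccccc1)CCC(C)(C)O2` gives 19 nM, the lowest of the three, with compound 2 the nearest and compound 1 the furthest, both beyond the scatter.

Going by the values given here, the one step measured within the shared core is a 6.3-fold lower number from compound 2 to compound 3 (0.80 log units; beyond the scatter), the change being phenethyl in place of phenyl on a saturated chain carbon bound to an amine nitrogen. Compound 1 differs in several places from the rest and is not used for comparison.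

Compound 4 `COc1cc2c(cc1C(C)NCCCCc1ccccc1)CCC(C)(C)O2` is not yet measured. It differs from compound 3 by benzyl in place of phenyl on a saturated chain carbon, three bonds along the chain from an amine nitrogen. Among the compounds with values here, this is the same kind of lengthening as the measured step, carried one bond further, but no second step of this kind exists in the set, so whether the gain continues is open. A step near the scatter, toward a lower number, is expected: a 1.4-fold lower number from compound 3 to compound 4 (0.13 log units; within the scatter). Compound 4 is estimated at 14 nM, between 5 nM and 50 nM.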

Compound 4, inhibition constant: 115 nM
The estimate for compound 4 lay 8.2-fold (0.91 log units) below the measured number, and the stated range ends below it.
By their numbers in this assay, from the lowest: compound 3; then compounds 4, 2 and 1 (each within the scatter of the next).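

In this assay, the chain at this position does not keep giving a lower number as it lengthens: the step is a 6.1-fold higher number from compound 3 to compound 4 (0.78 log units; beyond the scatter), so the gain seen in the earlier step is reversed. The longest chain also gives back all of that gain, with a 1.0-fold lower number from compound 2 to compound 4 (0.01 log units; within the scatter), which leaves compound 3 alone among the three compounds of the shared core and places the lowest number at the intermediate chain, not at either end of the measured range. No measurement shown here accounts for this reversal.

On these data alone, what remains open is whether the low number is tied to this chain alone, since a phenethyl group on the amine nitrogen would fill the gap between compound 2 and compound 3. As far as these compounds go, it is also open whether a pyridine ring in place of the end phenyl ring, or an ether oxygen within the chain, would hold the level of compound 3 at 19 nM.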